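The compounds below may be only part of what the source reports. "The series", "measured", "known", "first", "only" and "open" are said of these compounds alone.

Compound 3, with the structure `CC1CCN(c2c(S(=O)(=O)c3cccc(Cl)c3)cnc3ccc(Cl)cc23)CC1`, gives 92% in an assay on isolated protein for displacement of a labelled ligand from metabotropic glutamate receptor 5 (Homo sapiens), with a stated time of 60 min, tested at 1 uM (a higher number here means more inhibition at the concentration tested (going by the name of the read-out), a lower number less inhibition), the highest of three numbers but within the scatter of both neighbours. Compound 1, with the structure `CC1CCN(c2c(S(=O)(=O)c3ccccc3)cnc3ccccc23)CC1`, gives 89.2% in this assay, and compound 2, with the structure `CC1CCN(c2c(S(=O)(=O)c3cc(Cl)cc(Cl)c3)cnc3ccc(Cl)cc23)CC1`, gives 88%. The step to compound 4, with the structure `CC1CCN(c2c(S(=O)(=O)c3ccccc3)cnc3ccc(Cl)cc23)CC1`, is hydrogen in place of chloro on an aromatic carbon. One measured step removes a chloro from the same ring: a number 4 percentage points higher from compound 2 to compound 3 (within the scatter). Compound 1 also carries an unsubstituted phenyl there and sits close to compound 3 in this assay. No step beyond the scatter is therefore expected, with a number 2 percentage points lower from compound 3 to compound 4 (within the scatter). Compound 4 is estimated at 90%, with a range from 82% to 96%.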

Compound 4, a percentage reported as inhibition, at one concentration (the size of the read-out at that concentration, not a potency): 59%
For compound 4 the middle estimate is 31 percentage points above the measured one, and the stated range ends above it.
By their numbers in this assay, from the lowest: compound 4; then compounds 2, 1 and 3 (each within the scatter of the next).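

With a chloro on the shared core, the phenyl ring appears to need a chloro of its own in this assay: there is a number 33 percentage points lower from compound 3 to compound 4 (beyond the scatter), and a number 29 percentage points lower from compound 2 to compound 4 (beyond the scatter). The core chloro alone marks the same drop, with a number 30.2 percentage points lower from compound 1 to compound 4 (beyond the scatter). Swapping a chloro for hydrogen therefore has no fixed size here, and its size depends on where the other chloro atoms stand: the same change on two cores in this assay, a number 4 percentage points higher (within the scatter) from compound 2 to compound 3 and a number 30.2 percentage points higher (beyond the scatter) from compound 4 to compound 1, 26.2 percentage points apart, beyond the scatter of two such steps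

As far as these compounds go, whether a methyl or a methoxy group in place of that chloro keeps the inhibition stays open. So does what a chloro there does when the core carries none.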